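Trading a Sulfonamide for a Hydroxyl Group

The compounds below may be only part of what the source reports. "The series", "measured", "known", "first", "only" and "open" are said of these compounds alone.

Three compounds share one core and differ only in the group on a saturated ring carbon of the five-membered ring. Compound 1 `COc1ccc(-c2c(C)nc3c(N4CC[C@@H](NC(=O)OC5CCCCC5)C4)cc(C)nn23)cc1OC` carries a cyclohexyloxycarbonyl on an amine nitrogen. In an ADME assay on microsomes from liver (Mus musculus) for metabolic stability, read by LC-MS, with NADPH named in the record, with a stated time of 60 min, tested at 1 uM, in the absence of a further agent (on this read-out lower numbers stand for a less stable compound and higher numbers for a more stable compound), compound 1 gives a value that is a limit of the assay, > 95%. Compound 2 `COc1ccc(-c2c(C)nc3c(N4CC[C@@H](NS(C)(=O)=O)C4)cc(C)nn23)cc1OC` has a methylsulfonyl there instead. In this assay compound 2 also reaches a limit, > 95%. Compound 3 `COc1ccc(-c2c(C)nc3c(N4CC[C@@H](NS(=O)(=O)c5ccc(NC(C)=O)cc5)C4)cc(C)nn23)cc1OC` bears a 4-acetamidophenyl on the sulfonyl sulfur. In this assay compound 3 again reaches a limit, > 95%. The two measured steps, a step that the two limits leave unreadable from compound 1 to compound 2 and a step that the two limits leave unreadable from compound 2 to compound 3, therefore tell nothing about size; every value shown reaches (the limit of > 95% in this assay, at which 3 of the 3 values shown sit).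

Compound 4 `COc1ccc(-c2c(C)nc3c(N4CC[C@@H](O)C4)cc(C)nn23)cc1OC` is not yet measured. Its change from compound 2 is hydroxy in place of methanesulfonamido on a saturated ring carbon. Among the compounds with values here, the measured steps bear on it only in that each group tried on that carbon left the compound at the same limit, so a large loss is not expected, though a much smaller group now stands there and the earlier steps cannot show how far a value might drop. For compound 4 a step of a number at least 10 percentage points lower from compound 2 to compound 4 (that floor lies within the scatter) is expected in this assay. Compound 4 is therefore estimated at 85%, with a range from 60% to 98%.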

Compound 4, percent of the compound remaining: > 95%
Compound 4: only a limit was reported; the forecaster's own chance of this, stated with the estimate: 45%; at least 10 percentage points between middle value and limit.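

In this assay compound 4 gives > 95%, which is a limit of the assay. No step from compound 1 or compound 2 to compound 4 can be read, as all the values share one limit: the limit of > 95% in this assay, at which 4 of the 4 values shown sit.

The compounds shown leave open whether hydroxy in place of methanesulfonamido changes the percent of compound remaining at all, and by how much.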